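The source may report more compounds than this note shows. Statements on the series, on what has been measured and on what is new or still open speak of the compounds shown alone.

Of the compounds shown here, three built on a shared core have been tested so far in a functional assay (aorta) with Oryctolagus cuniculus as the target; a lower number here means tighter binding, a higher number weaker binding. Compound 1 `COc1cc(C(C)=O)ccc1OCCCN1CCC(C(c2ccc(F)cc2)c2ccc(F)c(F)c2)CC1` gives 1.26 nM, compound 2 `COc1cc(C(C)=O)ccc1OCCCN1CCC(C(c2ccc(F)cc2)C2CCCCC2)CC1` gives 5.01 nM, and compound 3 `COc1cc(C(C)O)ccc1OCCCN1CCC(C(c2ccc(F)cc2)c2ccc(F)cc2)CC1` gives 10 nM. The values of compound 2 and compound 3 lie within the usual scatter of each other, while compound 3 sits clearly higher than compound 1, which means weaker binding.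

The next compound, compound 4 `N#Cc1ccc(OCCCN2CCC(C(c3ccc(F)cc3)c3ccc(F)cc3)CC2)cc1`, differs from compound 3 on an oxygen on a saturated carbon, with 4-cyanophenyl in place of 4-(1-hydroxyethyl)-2-methoxyphenyl (4-cyanophenyl in place of 4-(1-hydroxyethyl)-2-methoxyphenyl on an oxygen on a saturated carbon). For the measured compounds named here, only one measured step is available, a 4.0-fold higher number from compound 1 to compound 2 (0.60 log units; beyond the scatter), and it puts cyclohexyl in place of 3,4-difluorophenyl, which is a different place in the molecule. That step can therefore serve only as a rough guide to how large a single change may be in this series. Going by the values given here, no measured pair of compounds varies the group on that oxygen, so the data give no firm direction. In this assay, a small step of uncertain direction is expected, perhaps no larger than that modest one. The estimated change is a 1.5-fold higher number from compound 3 to compound 4 (0.18 log units; within the scatter). For compound 4 the expected value is 15 nM, with an estimated range of 3 nM to 70 nM.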

Compound 4, dissociation constant: 5.01 nM
Compound 4: middle estimate off by 3.0-fold (0.48 log units), on the high side, within the range that was stated.
By their numbers in this assay, from the lowest: compound 1; then compounds 2, 4 and 3 (each within the scatter of the next).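

At the group on an oxygen on a saturated carbon, the one swap shown, 4-cyanophenyl in place of 4-(1-hydroxyethyl)-2-methoxyphenyl, gives a 2.0-fold lower number from compound 3 to compound 4 (0.30 log units; within the scatter) in this assay and so cannot be told apart from the ordinary spread of repeated measurements. For the compounds shown here, the earlier step concerned a different place, the saturated chain carbon that carries the cyclohexyl or 3,4-difluorophenyl group, so this is the first reading at the oxygen, and the swap there is a large one on paper: the group goes from 11 heavy atoms to 8, from 1 hydrogen-bond donor to 0, and gains a nitrile. For this one pair, then, a substantial rewrite of the group leaves no readable change in the number, and no separate data here explain that outcome.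

As far as these compounds go, this single swap alters the methoxy, the 1-hydroxyethyl and the nitrile together, so the effect of each part stays unknown, and the parts could even offset one another. From the compounds shown here alone, it also remains open whether the same holds for quite different groups on that oxygen, such as 4-aminophenyl or 4-carboxyphenyl, or for a longer chain leading to the oxygen.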